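Quinoline carboxamides at the affinity limit

The compounds below may be only part of what the source reports. "The series", "measured", "known", "first", "only" and "open" are said of these compounds alone.

Compound 1, `COc1ccc(CNC(=O)c2cnc3nc(C)ccc3c2O)cc1`, in an assay for binding affinity to adenosine receptor A1 (Bos taurus) (on this read-out lower numbers stand for stronger inhibition and higher numbers for weaker inhibition), gives > 10000 nM, a limit of the assay.
Compound 2, `CC(=O)Nc1ccc2c(O)c(C(=O)NCc3ccccc3)cnc2n1`, in this assay gives > 10000 nM, also a limit.

Among the measured compounds shown here, compound 2 stands at the limit of > 10000 nM in this assay, at which 2 of the 2 values shown sit; no number places it relative to compound 1, and no single-change step between measured compounds is available. Compound 3, `O=C(NCc1ccccc1)c1cnc2nc(Cl)ccc2c1O`, differs from compound 2 by chloro in place of acetamido on an aromatic carbon. With both measured values at the limit, no step size in this assay can be read from the series, and the expected step is an at least 1.2-fold lower number from compound 2 to compound 3 (0.09 log units; that floor lies within the scatter), not beyond the scatter. Compound 3 is expected to give about 8000 nM, in the range 2000 nM to 30000 nM.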

Compound 3, inhibition constant: 586 nM
The estimate for compound 3 lay 14-fold (1.14 log units) above the measured number; the measured number lies below the stated range.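

On an aromatic carbon next to the ring nitrogen, chloro in place of acetamido gives a real number in this assay where the acetamido compound gave none, with an at least 17-fold lower number from compound 2 to compound 3 (1.23 log units; beyond the scatter) as the step. That step is a bound only, since the value of compound 2 is a limit. Activity at this receptor is therefore reachable on the shared core with the benzyl amide kept unchanged.

Going by these compounds, how far the gain comes from losing acetamido rather than from gaining chloro stays open. Also open, on these data alone, is how bromo, fluoro or an amine at this position would compare with chloro.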